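Swapping a difluorophenyl for a methylphenyl on a fused core

A few compounds are considered here, and "the series" means these few. Any claim that something is new, unique, unknown or untested is made for them only; others in the source may bear on it.

The measured compounds and their values:
compound 1 `CC#CC(CC(=O)O)c1ccc(OCc2ccc3nc(-c4ccc(F)cc4F)cn3c2)cc1`: 825 nM
compound 2 `CC#CC(CC(=O)O)c1ccc(OCc2ccn3cc(-c4cccc(C)c4)nc3c2)cc1`: 1510 nM
compound 3 `CC#CC(CC(=O)O)c1ccc(OCc2ccn3cc(-c4cc(F)ccc4F)nc3c2)cc1`: 639 nM

All three were tested in an assay on isolated protein for agonist activity at Free fatty acid receptor 1 (Homo sapiens); on this read-out higher numbers stand for an effect only at larger amounts of compound and lower numbers for an effect already at smaller amounts. Compound 1 gives the second highest of the three numbers; its gap to compound 3 and its gap to compound 2 both lie within the usual scatter, so no order among them can be claimed. Compound 4 `CC#CC(CC(=O)O)c1ccc(OCc2ccc3nc(-c4cccc(C)c4)cn3c2)cc1` has not been measured. It differs from compound 1 in one place: 3-methylphenyl in place of 2,4-difluorophenyl on an aromatic carbon.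

Compounds 2 and 3 share a core that is related to, but not the same as, that of compound 1 and compound 4. Going by the values given here, their single step of a 2.4-fold lower number from compound 2 to compound 3 (0.37 log units; beyond the scatter) is the closest guide, and it runs in the opposite direction to the present change. Taken in reverse, it suggests a modest rise in the number, though the core difference makes this uncertain. A step of a 2.1-fold higher number from compound 1 to compound 4 (0.31 log units; beyond the scatter) is therefore expected. Compound 4 is estimated at 1700 nM, with a likely range from 800 nM to 3600 nM.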

Compound 4, half-maximal effective concentration: 1050 nM
For compound 4 the middle estimate is 1.6-fold (0.21 log units) above the measured one; the measured number falls inside the stated range.
By their numbers in this assay, from the lowest: compounds 3, 1, 4 and 2 (each within the scatter of the next, the first and the last beyond it).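

On the core of compound 1, 3-methylphenyl in place of 2,4-difluorophenyl gives a 1.3-fold higher number from compound 1 to compound 4 (0.10 log units; within the scatter) in this assay, so on this aromatic carbon of the five-membered ring the two groups cannot be told apart. Going by these compounds alone, on the related core of compounds 2 and 3, the one earlier swap of a methylphenyl and a difluorophenyl, a 2.4-fold lower number from compound 2 to compound 3 (0.37 log units; beyond the scatter), lies beyond the scatter, so that step does not carry over as a clear change here, though its fluorines sit differently. No measurement at hand explains this difference between the two cores.

As far as these compounds go, whether any group at this position can move the number clearly on the core of compound 1 stays open. A ring carrying an amine or a nitrile, or a longer chain in place of the ring, would test this.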